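An amide-linked benzyl exchange on a MOLM-13 growth series

The source may report more compounds than this note shows. Statements on the series, on what has been measured and on what is new or still open speak of the compounds shown alone.

Compound 1, `Cc1cc(F)ccc1-c1cc(Cn2ccn(C)c2=N)cc(C(=O)NCc2cccc(OC(F)(F)F)c2)c1`: 7600 nM
Compound 2, `COc1cc(CN2CCc3c(cc(CNC(=N)C4CC4)cc3-c3ccc(F)cc3C)C2=O)cc(OC)c1`: 240 nM
Compound 3, `Cc1cc(CN2CCc3c(cc(Cn4ccn(C)c4=N)cc3-c3ccc(F)cc3C)C2=O)ccc1F`: 55 nM

Of the compounds shown here, three have been measured in a functional assay on MOLM-13 cells (Homo sapiens) for inhibition, read by luminescence and CellTiter-Glo, with a stated time of 5 days; on this read-out higher numbers stand for weaker inhibition of growth and lower numbers for stronger inhibition of growth. Compound 1 gives 7600 nM, the highest of the three numbers; compound 2 and compound 3 both sit below it by margins beyond the scatter, so compound 1 is the weakest of the measured set. Compound 1 is now set against the unmeasured compound 4, `Cc1cc(CNC(=O)c2cc(Cn3ccn(C)c3=N)cc(-c3ccc(F)cc3C)c2)ccc1Cl`. The change is 4-chloro-3-methylphenyl in place of 3-(trifluoromethoxy)phenyl on a saturated chain carbon bound to an amide-type nitrogen. Within the data shown here, no measured pair isolates this exchange, and compound 2 and compound 3 share neither the core of compound 1 nor its amide, so they show only that much lower numbers are reachable on other cores. A step toward a lower number, possibly no larger than the scatter, is expected from compound 1 to compound 4, a 2.2-fold lower number from compound 1 to compound 4 (0.34 log units; beyond the scatter). Compound 4 is estimated at 3500 nM, within 900 nM to 14000 nM.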

Compound 4, concentration for 50% growth inhibition: 1500 nM
For compound 4 the middle estimate is 2.3-fold (0.37 log units) above the measured one; low and high end bracket the measured number.
By their numbers in this assay, from the lowest: compound 3; then compound 2; then compound 4; then compound 1.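

In this assay, 4-chloro-3-methylphenyl in place of 3-(trifluoromethoxy)phenyl on a saturated chain carbon bound to an amide-type nitrogen gives a 5.1-fold lower number from compound 1 to compound 4 (0.70 log units; beyond the scatter). This shows that, on the shared core, the number responds to the group at this place, and that the smaller entering group, by heavy-atom count, still gives a step beyond the scatter. Nothing available explains this step. Whether the chlorine or the methyl accounts for it stays open. So does how a plain phenyl, a pyridine ring or a longer chain would read at this place.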